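Spiro-hydantoin series: replacing the piperazine amide by an open chain

The compounds below may be only part of what the source reports. "The series", "measured", "known", "first", "only" and "open" are said of these compounds alone.

Measured compounds:
compound 1 `COC(=O)CCCNC(=O)CN1CN(c2ccccc2)C2(CCN(C(=O)c3ccc(C4CCCCC4)cc3)CC2)C1=O`, 2500 nM
compound 2 `CC(C)(C)OC(=O)NCCCCNC(=O)CN1CN(c2ccccc2)C2(CCN(C(=O)c3ccc(C4CCCCC4)cc3)CC2)C1=O`, 4600 nM
compound 3 `CS(=O)(=O)N1CCN(C(=O)CN2CN(c3ccccc3)C3(CCN(C(=O)c4ccc(C5CCCCC5)cc4)CC3)C2=O)CC1`, 6300 nM

In an assay on HEK293 cells for displacement of a labelled ligand from NPC1-like intracellular cholesterol transporter 1 (Homo sapiens) (on this read-out higher numbers stand for weaker inhibition and lower numbers for stronger inhibition), compound 3 gives the highest of the three numbers: its step from compound 2 lies within the scatter, whereas the step from compound 1 does not (a 2.5-fold higher number from compound 1 to compound 3 (0.40 log units; beyond the scatter)). Compound 4 `CS(=O)(=O)NCCCNC(=O)CN1CN(c2ccccc2)C2(CCN(C(=O)c3ccc(C4CCCCC4)cc3)CC2)C1=O` differs from compound 3 at the carbonyl carbon of the shared core's side chain: (3-(methanesulfonamido)propyl)amino in place of 4-(methylsulfonyl)piperazin-1-yl on a carbonyl carbon.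

Within the data shown here, two measured steps bear on this change. The step of a 2.5-fold higher number from compound 1 to compound 3 (0.40 log units; beyond the scatter) moved from an open (3-(methoxycarbonyl)propyl)amino chain to the 4-(methylsulfonyl)piperazin-1-yl ring; the move to compound 4 reverses that direction, reopening the chain, though with a methanesulfonamido terminus instead of methoxycarbonyl. The step of a 1.8-fold higher number from compound 1 to compound 2 (0.26 log units; within the scatter) shows that exchanging the terminus of such an open chain stayed within the scatter. Taken together, compound 4 is expected to come in near compound 1, i.e. a modest downward step a 2.1-fold lower number from compound 3 to compound 4 (0.32 log units; beyond the scatter) in this assay, with the terminus exchange adding no step beyond the scatter.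

Compound 4 is therefore estimated at 3000 nM in this assay, within a range of 1200 nM to 7500 nM.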

Compound 4, half-maximal inhibitory concentration: 3800 nM
Compound 4: middle estimate off by 1.3-fold (0.10 log units), on the low side, within the range that was stated.
By their numbers in this assay, from the lowest: compounds 1, 4, 2 and 3 (each within the scatter of the next, the first and the last beyond it).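

Notes on the carbonyl-carbon side chain: in this assay, reopening the ring as (3-(methanesulfonamido)propyl)amino gives a 1.7-fold lower number from compound 3 to compound 4 (0.22 log units; within the scatter), so an open chain at this place does not by itself separate from 4-(methylsulfonyl)piperazin-1-yl, even though the earlier 2.5-fold higher number from compound 1 to compound 3 (0.40 log units; beyond the scatter) lay beyond the scatter. The open-chain compounds cannot be told apart in this assay, with a 1.5-fold higher number from compound 1 to compound 4 (0.18 log units; within the scatter) and a 1.2-fold lower number from compound 2 to compound 4 (0.08 log units; within the scatter), so methanesulfonamido joins methoxycarbonyl and ((tert-butoxycarbonyl)amino)methyl in a set of chain ends that this read-out does not resolve; compound 1 and compound 3 alone remain separated beyond the scatter. No measurement at hand accounts for these numbers.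

Compound 1 and compound 3 differ in both the ring and the chain end, so a 4-(methoxycarbonyl)piperazin-1-yl group would be needed to assign their gap to one or the other. From the compounds shown here alone, it also remains open whether a free primary amine or a carboxylic acid at the chain end, or a longer chain, would move the number beyond the scatter of this set.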